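A few compounds are considered here, and "the series" means these few. Any claim that something is new, unique, unknown or untested is made for them only; others in the source may bear on it.

Measured in an ADME assay on HepG2 cells (Homo sapiens) for cytotoxicity, with a stated time of 72 h; a lower number here means that less compound is needed, a higher number that more compound is needed for the effect:
Compound 1 `O=C(Nc1ccc(F)c(-c2nc3ccccc3s2)c1)c1cc([N+](=O)[O-])ccc1Cl`: > 25000 nM, a limit of the assay
Compound 2 `O=C(Nc1ccc(O)c(-c2nc3ccccc3s2)c1)c1cc([N+](=O)[O-])ccc1Cl`: > 25000 nM, a limit of the assay

Compound 2 therefore stands only at a limit, not at a number. Compound 3 `O=C(Nc1cccc(-c2nc3ccccc3s2)c1)c1cc([N+](=O)[O-])ccc1Cl` differs from it by hydrogen in place of hydroxy on an aromatic carbon, with hydrogen in place of hydroxy on an aromatic carbon. Among the measured compounds shown here, the one measured step at this place is a step that the two limits leave unreadable from compound 1 to compound 2, so its size gives no guide. All that is shown is the limit of > 25000 nM in this assay, at which 2 of the 2 values shown sit. The estimated step is a number no higher from compound 2 to compound 3 (the limit leaves the size open), and no change beyond the scatter is expected in this assay. Compound 3 is expected at about 25000 nM, with an estimated range from 12000 nM to 50000 nM.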

Compound 3, half-maximal effective concentration: > 27000 nM
Compound 3: only a limit was reported; the forecaster's own chance of this, stated with the estimate: 85%; at least 1.0-fold (0.03 log units) between middle value and limit.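

In this assay, among the compounds shown here, compound 1, compound 2 and compound 3 each gave only a limit of the assay, so no step among them can be read. On these data alone, the concentration at which any of them reaches the effect remains open.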